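The compounds below may be only part of what the source reports. "The series", "measured", "known", "first", "only" and "open" are said of these compounds alone.

Compound 1, `CS(=O)(=O)c1ccc(Nc2nccc(Nc3nc4ccc(F)cc4s3)n2)cc1`: in a functional assay on MCF7 cells (Homo sapiens) for antiproliferative activity, read by MTT assay, with a stated time of 48 h (on this read-out lower numbers stand for stronger inhibition and higher numbers for weaker inhibition), compound 1 gives > 60000 nM, which is a limit of the assay.
Compound 2, `Cc1ccc2nc(Nc3ccnc(Nc4ccc(S(C)(=O)=O)cc4)n3)sc2c1`: in this assay compound 2 gives > 50000 nM, which is a limit of the assay.

On the numbers shown, compound 1 stands only at a limit, and the one further value shown is a limit as well. Among the compounds with values here, the single measured step, a step that the two limits leave unreadable from compound 1 to compound 2, cannot be read because the limit of > 60000 nM in this assay, at which 1 of the 2 values shown sits, and the limit of > 50000 nM in this assay, at which 1 of the 2 values shown sits, leave its size unknown.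

Compound 3, `NS(=O)(=O)c1ccc(Nc2nccc(Nc3nc4ccc(F)cc4s3)n2)cc1`, differs from compound 1 by amino in place of methyl on a sulfonyl sulfur, the same difference cut one bond further out reading as methylsulfonyl to sulfamoyl. Within the data shown here, no measured step touches this place, and the one step that is measured is itself unreadable, so it gives no size to carry over. The expectation for compound 3 is therefore that it stays near the limit, with an estimated step of a number no higher from compound 1 to compound 3 (the limit leaves the size open). Compound 3 is expected at about 60000 nM, within a range of 15000 nM to 200000 nM.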

Compound 3, half-maximal inhibitory concentration: 10900 nM
Beside the measured number, compound 3's estimate is 5.5-fold (0.74 log units) above it, and the stated range ends above it.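

In this assay, the sulfonyl sulfur proves to be a place where a single change can be read: amino in place of methyl gives an at least 5.5-fold lower number from compound 1 to compound 3 (0.74 log units; beyond the scatter). Compound 3 is the first compound shown with a measured number rather than a limit, so the change from methylsulfonyl to sulfamoyl is the first step here with a readable lower bound. Its full size stays open because compound 1 stands only at a limit: the limit of > 60000 nM in this assay, at which 1 of the 3 values shown sits.

The compounds shown leave open whether sulfamoyl has a similar effect when methyl replaces fluoro on the aromatic carbon, as in compound 2, and the step between compound 1 and compound 2 cannot be read. They also leave open how an ethyl chain or a dimethylamino group on the sulfonyl sulfur would compare with amino.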